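This account rests on a few compounds, and the source may have more. Where it says the series, first, only, none or still open, it means among the compounds named here.

Compound 1 `CC1(C)CCC[C@]2(C)[C@@H](CC[C@@](C)(O)/C=C/c3cccc([N+](=O)[O-])c3)[C@](C)(O)CC[C@@H]12` carries a 3-nitrophenyl group on the double-bonded chain. In a functional assay on PC-3 cells (Homo sapiens) for cytotoxicity, read by MTT assay, with a stated time of 48 h (a lower number here means a stronger inhibitor, a higher number a weaker inhibitor), compound 1 gives 153 nM, the lowest number of the three measured. Compound 2 `COc1cccc(OC)c1/C=C/[C@](C)(O)CC[C@@H]1[C@@]2(C)CCCC(C)(C)[C@@H]2CC[C@@]1(C)O` gives 4000 nM and compound 3 `CC(C)(C)c1ccc(/C=C/[C@](C)(O)CC[C@@H]2[C@@]3(C)CCCC(C)(C)[C@@H]3CC[C@@]2(C)O)cc1` gives 3800 nM. Both swaps of the aromatic group away from 3-nitrophenyl gave large steps: a 26-fold higher number from compound 1 to compound 2 (1.42 log units; beyond the scatter) and a 25-fold higher number from compound 1 to compound 3 (1.40 log units; beyond the scatter). Compound 4 `CC1(C)CCC[C@]2(C)[C@@H](CC[C@@](C)(O)/C=C/c3ccc(F)cc3)[C@](C)(O)CC[C@@H]12` makes the change (4-fluorophenyl in place of 3-nitrophenyl on a double-bonded chain carbon bound to a double-bonded chain carbon). Because a 26-fold higher number from compound 1 to compound 2 (1.42 log units; beyond the scatter) and a 25-fold higher number from compound 1 to compound 3 (1.40 log units; beyond the scatter) both went strongly upward at this place, a similar upward step is expected for compound 4, though a 4-fluorophenyl has not been measured and the size is uncertain. The expected step is a 13-fold higher number from compound 1 to compound 4 (1.12 log units; beyond the scatter). For compound 4 in this assay the estimate is 2000 nM, with a range from 400 nM to 8000 nM.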

Compound 4, half-maximal inhibitory concentration: 82 nM
Compound 4: the middle estimate sits 24-fold (1.39 log units) above what was measured; the whole stated range lies above it.
By their numbers in this assay, from the lowest: compounds 4 and 1 (each within the scatter of the next); then compounds 3 and 2 (each within the scatter of the next).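

Leaving 3-nitrophenyl does not by itself cost activity at this place: with 4-fluorophenyl there is a 1.9-fold lower number from compound 1 to compound 4 (0.27 log units; within the scatter) and the two compounds cannot be told apart. What sits on the aromatic ring matters, as fluoro in place of tert-butyl gives a 46-fold lower number from compound 3 to compound 4 (1.67 log units; beyond the scatter) and 4-fluorophenyl in place of 2,6-dimethoxyphenyl gives a 49-fold lower number from compound 2 to compound 4 (1.69 log units; beyond the scatter) in the same series. No supporting data explain these differences. On these data alone, how an amine or a carboxylic acid on this aromatic ring would behave remains open, as does a plain phenyl ring with no added group.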